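From Hydroxymethyl to Sulfanyl: Compound 3 to Compound 4

The source may hold more compounds than are shown below. What is called first, only, known or untested is meant among the compounds shown, and "the series" means these compounds.

In an assay on isolated protein for inhibition of matrix metalloproteinase-9 (Homo sapiens) (on this read-out lower numbers stand for stronger inhibition and higher numbers for weaker inhibition), three compounds sharing one core have been measured. Compound 1 `C=C[C@@H]1OC(/C=C/c2ccc(Br)cc2)=N[C@H]1CO` gives 22000 nM, compound 2 `C=C[C@@H]1OC(c2ccc(Cl)cc2)=N[C@H]1CO` gives 33000 nM, and compound 3 `C=C[C@@H]1OC(/C=C/c2ccccc2)=N[C@H]1CO` gives 40000 nM. Compound 3 carries the highest of the three numbers, yet its gap to compound 2 and its gap to compound 1 each lie within the scatter, so no order among the three can be drawn from them. Among the compounds with values here, the single step between compounds that differ in one place, a 1.8-fold higher number from compound 1 to compound 3 (0.26 log units; within the scatter), concerns hydrogen in place of bromo on an aromatic carbon and is itself within the scatter.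

Compound 4 `C=C[C@@H]1OC(/C=C/c2ccccc2)=N[C@H]1S` differs from compound 3 by sulfanyl in place of hydroxymethyl on a saturated ring carbon. Within the data shown here, no measured step touches this exchange: the only recorded step, a 1.8-fold higher number from compound 1 to compound 3 (0.26 log units; within the scatter), alters a substituent on an aromatic carbon and says nothing about the five-membered ring. The numbers therefore give no guide to the size or direction of the step in this assay, and a wide range is expected around a number near that of compound 3. Compound 4 is estimated at 10000 nM, between 1500 nM and 60000 nM. The expected step is a 4.0-fold lower number from compound 3 to compound 4 (0.60 log units; beyond the scatter).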

Compound 4, inhibition constant: 94000 nM
Compound 4: middle estimate off by 9.4-fold (0.97 log units), on the low side; the measured number lies above the stated range.
By their numbers in this assay, from the lowest: compounds 1, 2 and 3 (each within the scatter of the next); then compound 4.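

In this assay, the change on the saturated ring carbon gives the first step among these compounds that lies beyond the scatter: sulfanyl in place of hydroxymethyl produces a 2.4-fold higher number from compound 3 to compound 4 (0.37 log units; beyond the scatter), a modest step towards weaker inhibition. The exchange alters the size of the group, since hydroxymethyl leaves with 2 heavy atoms and sulfanyl enters with 1 heavy atom, and replaces oxygen with sulfur, while each group has 1 hydrogen-bond donor, 1 hydrogen-bond acceptor and no net charge, so these counts do not distinguish the two compounds. Nothing available explains the rise in the number.

This single exchange cannot separate the loss of the carbon from the change from oxygen to sulfur, and a hydroxy group or a sulfanylmethyl group at this carbon would pull those two apart. It also leaves open how an amine, a carboxylic acid or a longer chain such as hydroxyethyl would read at this position, and whether the same exchange would give a similar step on the bromo-bearing core of compound 1.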